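The source may hold more compounds than are shown below. What is called first, only, known or untested is meant among the compounds shown, and "the series" means these compounds.

Compound 1 (`CCCC/C=C\CCCCCCCCCc1cc(=O)c2c(O)cc(OCOC)cc2o1`) gives > 67200 nM in a functional assay on MCF7 cells (Homo sapiens) for antiproliferative activity, read by MTT assay (a higher number here means a weaker inhibitor, a lower number a stronger inhibitor), and that figure is a limit, not a number. Among the compounds with values here, it stands at the limit of > 67200 nM in this assay, at which 1 of the 2 values shown sits, and offers no measured number to step from. Compound 2 (`CCCC/C=C\CCCCCCCCCc1cc(=O)c2c(O)cc(O)cc2o1`) gives 17500 nM in this assay as a measured number. Within the data shown here, the one measured step is an at least 3.8-fold lower number from compound 1 to compound 2 (0.58 log units; beyond the scatter) with hydrogen in place of methoxymethyl on an oxygen on an aromatic ring. Compound 3 (`CCCCC/C=C\C/C=C\CCCCCCCc1cc(=O)c2c(O)cc(OCOC)cc2o1`) keeps that methoxymethyl and changes the chain instead: deca-1,4-dien-1-yl in place of oct-3-en-1-yl on a saturated chain carbon, seven bonds along the chain from an aromatic carbon. Among the measured compounds shown here, no measured step touches the chain, so the expectation rests on compound 1 at > 67200 nM as a limit: no step beyond the scatter is expected in this assay and another limit is quite possible. The expected step is a step that the limit leaves unreadable from compound 1 to compound 3 as estimated here. For compound 3 the estimated value is 70000 nM with an expected range from 30000 nM to 150000 nM in the same read-out.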

Compound 3, half-maximal inhibitory concentration: > 67200 nM
Compound 3: no number, only a limit; the forecaster's own chance of this, stated with the estimate: 65%; the middle value lies beyond the limit too.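

Compound 3 stays at a limit in this assay, like compound 1, so no step can be read between compound 1 and compound 3: the limit of > 67200 nM in this assay, at which 2 of the 3 values shown sit.

The compounds shown leave open whether deca-1,4-dien-1-yl in place of oct-3-en-1-yl changes the read-out at all, with or without the methoxymethyl.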